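Replacing 3-chlorophenyl with 2-fluorophenyl on the amine nitrogen

The compounds below may be only part of what the source reports. "The series", "measured", "known", "first", "only" and "open" are said of these compounds alone.

Compound 1 `Cc1cccc(NNC(=O)c2ccccc2NS(=O)(=O)c2cnc(O)nc2O)c1` reads > 20000 nM in a functional assay on SGC-7901 cells (Homo sapiens) for antiproliferative activity, read by MTT assay, with a stated time of 24 h (a lower number here means a stronger inhibitor, a higher number a weaker inhibitor), which is a limit of the assay and not a number. Among the measured compounds shown here, compound 2 `O=C(NNc1cccc(Cl)c1)c1ccccc1NS(=O)(=O)c1cnc(O)nc1O` gives 10800 nM in this assay as the only actual number so far, so its standing cannot be fixed against a second measured value. The other reading sits at a limit (the limit of > 20000 nM in this assay, at which 1 of the 2 values shown sits). For the measured compounds named here, the only measured step, chloro in place of methyl on an aromatic carbon, is an at least 1.8-fold lower number from compound 1 to compound 2 (0.26 log units; that floor lies within the scatter) and its floor lies within the scatter.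

Compound 3 `O=C(NNc1ccccc1F)c1ccccc1NS(=O)(=O)c1cnc(O)nc1O` carries 2-fluorophenyl in place of 3-chlorophenyl on an amine nitrogen, with the shared core unchanged. The measured step altered this same aryl group but exchanged a different pair of groups, so it bears only loosely on this change and sets no direction. Taking compound 2 at 10800 nM as the anchor, no step beyond the scatter is expected in this assay. The estimated shift is small (a 1.2-fold higher number from compound 2 to compound 3 (0.08 log units; within the scatter)). For compound 3 the estimated value is 13000 nM (expected range 6000 nM to 27000 nM).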

Compound 3, half-maximal inhibitory concentration: > 20000 nM
Compound 3: a limit, no number (the forecaster's own chance of this, stated with the estimate: 25%); middle value at least 1.5-fold (0.18 log units) away from the limit.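

Compound 3 reads > 20000 nM in this assay, which is a limit of the assay and not a number. Exchanging 3-chlorophenyl for 2-fluorophenyl on the amine nitrogen gives an at least 1.8-fold higher number from compound 2 to compound 3 (0.26 log units; that floor lies within the scatter), so only a floor is known for this change, and that floor does not clear the scatter. Among the compounds shown here, compound 2, at 10800 nM, stays the only compound here with a number. The step from compound 1 to compound 3 cannot be read, and the aryl group on this amine nitrogen now gives a limit in two of the three compounds: the limit of > 20000 nM in this assay, at which 2 of the 3 values shown sit.

Still open, as far as these compounds go, is whether the reading of compound 2 depends on the chlorine itself or on where it stands, a question that 2-chlorophenyl and 3-fluorophenyl on the same amine nitrogen would separate. Also open, from the compounds shown here alone, is how far this position tolerates other groups, such as 3-bromophenyl or a benzyl group, and whether any of them gives a number clearly lower than that of compound 2 in this assay.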